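The compounds below may be only part of what the source reports. "The series", "measured", "known", "first", "only" and "open" are said of these compounds alone.

Compounds measured so far in an assay for binding affinity to dual specificity mitogen-activated protein kinase kinase 4 (Homo sapiens), read by KINOMEscan, tested at 100 nM; on this read-out higher numbers stand for a weaker effect at the one concentration tested and lower numbers for a stronger effect:
compound 1, `CCCS(=O)(=O)Nc1ccc(F)c(C(=O)c2n[nH]c3ncc(-c4ccccc4)cc23)c1F`: 2.4%
compound 2, `CCCS(=O)(=O)Nc1ccc(F)c(C(=O)c2n[nH]c3ncc(-c4ccccc4C)cc23)c1F`: 7%
compound 3, `CCCS(=O)(=O)Nc1ccc(F)c(C(=O)c2n[nH]c3ncc(-c4ccc(C)c(C)c4)cc23)c1F`: 20%

Compound 3 gives the highest of the three numbers in this assay. Its nearest neighbour is compound 2, with a number 13 percentage points higher from compound 2 to compound 3 (beyond the scatter), and the furthest is compound 1, with a number 17.6 percentage points higher from compound 1 to compound 3 (beyond the scatter); both steps lie beyond the scatter, while a number 4.6 percentage points higher from compound 1 to compound 2 (within the scatter) does not. Across these three, each added methyl on the phenyl ring has gone with a higher number, though only compound 3 stands clearly apart.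

Compound 4, `CCCS(=O)(=O)Nc1ccc(F)c(C(=O)c2n[nH]c3ncc(-c4ccc(C(C)C)cc4)cc23)c1F`, has not yet been measured. It differs from compound 3 in one place: 4-isopropylphenyl in place of 3,4-dimethylphenyl on an aromatic carbon. Among the measured compounds shown here, no measured step tests a para group alone, so the steps from compound 1 and compound 2 to compound 3 are the only guide. They suggest that a larger substituent on that phenyl ring does not lower the number and may raise it somewhat. The account therefore expects for compound 4 a step of about a number 6 percentage points higher from compound 3 to compound 4 (within the scatter), most likely within the scatter, so that compound 4 is estimated at 26%, within a range from 8% to 60%.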

Compound 4, a percentage reported as activity, at one concentration (the size of the read-out at that concentration, not a potency): 17%
The estimate for compound 4 lay 9 percentage points above the measured number; low and high end bracket the measured number.
By their numbers in this assay, from the lowest: compounds 1, 2, 4 and 3 (each within the scatter of the next, the first and the last beyond it).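

In this assay, a single 4-isopropylphenyl group is enough to separate compound 4 from the unsubstituted phenyl of the first compound, with a number 14.6 percentage points higher from compound 1 to compound 4 (beyond the scatter), so a step beyond the scatter at this aromatic carbon does not require the two methyl groups of 3,4-dimethylphenyl. At the same time, compound 4 cannot be told apart from either of the two methyl-bearing compounds, with a number 3 percentage points lower from compound 3 to compound 4 (within the scatter) and a number 10 percentage points higher from compound 2 to compound 4 (within the scatter). Nothing available explains why these groups give these numbers.

On these data alone, it remains open whether 4-methylphenyl alone would already give such a step, or whether a tert-butyl group on the same phenyl ring would take the number further. As far as these compounds go, how a dimethylamino group or a carboxylic acid in that place would read also stays unknown.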